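A few compounds are considered here, and "the series" means these few. Any claim that something is new, unique, unknown or untested is made for them only; others in the source may bear on it.

Measured in a functional assay on MCF7 cells (Homo sapiens) for cytotoxicity, read by MTT assay, with a stated time of 48 h; on this read-out lower numbers stand for stronger inhibition and higher numbers for weaker inhibition: compound 1 `O=C(/C=C/c1cccc(F)c1)Nc1ccc(CC2=CC(=O)OC2)cc1` gives 39000 nM; compound 2 `C=C1OC(=O)C=C1Cc1ccc(NC(=O)/C=C/c2cccc(F)c2)cc1` gives 39000 nM; compound 3 `O=C(/C=C/c1ccc(F)cc1)Nc1ccc(CC2=CC(=O)OC2)cc1` gives 47900 nM.

Compound 4 `C=C1OC(=O)C=C1Cc1ccc(NC(=O)/C=C/c2ccc(F)cc2)cc1` has not yet been measured in this assay. It differs from compound 3 by a group of 7 heavy atoms (5 carbon, 2 oxygen; one five-membered non-aromatic ring with 1 hetero atom) in place of a group of 6 heavy atoms (4 carbon, 2 oxygen; one five-membered non-aromatic ring with 1 hetero atom), on a saturated chain carbon bound to an aromatic carbon. The same change already occurs once among the measured compounds: compound 2 arises from compound 1 by a group of 7 heavy atoms (5 carbon, 2 oxygen; one five-membered non-aromatic ring with 1 hetero atom) in place of a group of 6 heavy atoms (4 carbon, 2 oxygen; one five-membered non-aromatic ring with 1 hetero atom), on a saturated chain carbon bound to an aromatic carbon, and that step in this assay was no change at the digits printed from compound 1 to compound 2 (within the scatter). The place of the change is the same in both pairs, so it is the same change, not merely the same kind. The two cores themselves differ by 4-fluorophenyl in place of 3-fluorophenyl on a double-bonded chain carbon bound to a double-bonded chain carbon, and that step in this assay was a 1.2-fold higher number from compound 1 to compound 3 (0.09 log units; within the scatter). All three measured values sit close together, with no difference beyond the scatter. Because the earlier step was no change at the digits printed from compound 1 to compound 2 (within the scatter), the step from compound 3 to compound 4 is expected to be similarly small, estimated at a 1.0-fold lower number from compound 3 to compound 4 (0.02 log units; within the scatter). Compound 4 is therefore expected to give about 46000 nM in this assay, most likely between 22000 nM and 95000 nM.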

Compound 4, half-maximal inhibitory concentration: 4430 nM
Compound 4: the middle estimate sits 10-fold (1.02 log units) above what was measured; the whole stated range lies above it.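

In this assay, exchanging the ring group on the core bearing 4-fluorophenyl gives an 11-fold lower number from compound 3 to compound 4 (1.03 log units; beyond the scatter), a far larger step than the same exchange gives on the core bearing 3-fluorophenyl: the same change on two cores in this assay, no change at the digits printed (within the scatter) from compound 1 to compound 2 and an 11-fold lower number (1.03 log units; beyond the scatter) from compound 3 to compound 4, 11-fold (1.03 log units) apart, beyond the scatter of two such steps. Seen from the other side, 4-fluorophenyl in place of 3-fluorophenyl gives an 8.8-fold lower number from compound 2 to compound 4 (0.94 log units; beyond the scatter) when the larger ring group is present, yet no step beyond the scatter when the smaller one is: the same change on two cores in this assay, a 1.2-fold higher number (0.09 log units; within the scatter) from compound 1 to compound 3 and an 8.8-fold lower number (0.94 log units; beyond the scatter) from compound 2 to compound 4, 11-fold (1.03 log units) apart, beyond the scatter of two such steps. So in these four compounds the change did not carry over from one core to the other, and the effect of each change depended on the other; this does not show why, and a single pair of cores gives no rule for the wider series.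

The compounds shown leave open whether the same large step would appear with a chlorine or a methoxy group on the phenyl ring instead of fluorine, or with an unsubstituted phenyl ring. They also leave open which part of the entering ring group matters.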